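The compounds below may be only part of what the source reports. "The series", "measured", "known", "first", "only" and "open" are said of these compounds alone.

Of the compounds shown here, two built on a shared core have been tested in a functional assay on PANC-1 cells (Homo sapiens) for inhibition, read by MTT assay, with a stated time of 24 h, tested at 10 uM; on this read-out lower numbers stand for less inhibition and higher numbers for more inhibition at the one concentration tested (going by the name of the read-out). Compound 1 `CC(C)=CCC1Cc2c(OCCCNS(=O)(=O)c3ccc(Cl)cc3)cc(=O)n(CCCO)c2CC1(C)C` gives 9.8%. Compound 2 `CC(C)=CCC1Cc2c(OCCCOc3ccc(Cl)cc3)cc(=O)n(CCCO)c2CC1(C)C` gives 0%, the lower of the two numbers, although the step of a number 9.8 percentage points lower from compound 1 to compound 2 (within the scatter) is within the scatter, so the two compounds cannot be told apart on this read-out. Compound 3 `CC(C)=CCC1Cc2c(OC(=O)Nc3ccc(Cl)c(Cl)c3)cc(=O)n(CCCO)c2CC1(C)C` is the next compound, differing from compound 2 in one place: (3,4-dichlorophenyl)carbamoyl in place of 3-(4-chlorophenoxy)propyl on an oxygen on an aromatic ring. For the measured compounds named here, the only measured step, from compound 1 to compound 2, exchanged the group at the far end of the chain and moved the read-out by a number 9.8 percentage points lower from compound 1 to compound 2 (within the scatter), which gives no sign of a large effect; it also does not resemble the present change, so no direction can be drawn from it. For compound 3 the step in this assay is therefore expected to be a number 10 percentage points higher from compound 2 to compound 3 (within the scatter), within the scatter. Compound 3 is estimated to give 10%, between 0% and 35%.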

Compound 3, a percentage reported as inhibition, at one concentration (the size of the read-out at that concentration, not a potency): 1.8%
Compound 3: the middle estimate sits 8.2 percentage points above what was measured, within the range that was stated.
By their numbers in this assay, from the lowest: compounds 2, 3 and 1 (each within the scatter of the next).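

Placing (3,4-dichlorophenyl)carbamoyl in place of 3-(4-chlorophenoxy)propyl on the oxygen on the aromatic ring gives a step of a number 1.8 percentage points higher from compound 2 to compound 3 (within the scatter) in this assay. This exchanges the whole group on that oxygen, not only the far end of the chain, and the two groups differ in make-up, with the entering one bringing a hydrogen-bond donor and a second chlorine, yet the read-out does not tell compound 2 and compound 3 apart. No measurement at hand bears on this result.

From the compounds shown here alone, whether any group on this oxygen can give a step beyond the scatter remains open. An amine or a carboxylic acid at the end of the chain, or a longer chain, would probe this, while a 4-chlorophenylcarbamoyl group would separate the second chlorine from the carbamoyl link.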